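Cytotoxicity notes: ethyl for methyl on the oxadiazole

The compounds below may be only part of what the source reports. "The series", "measured", "known", "first", "only" and "open" are said of these compounds alone.

In an ADME assay on H1-HeLa cells (Homo sapiens) for cytotoxicity, read by MTT assay, with a stated time of 3 days (a lower number here means that less compound is tolerated, a higher number that more compound is tolerated), compound 1 `CNC(=O)c1cc(Oc2ccc3c(C)c(-c4noc(C(C)C)n4)sc3c2)ccn1` gives 5500 nM. Compound 2 `CNC(=O)c1cc(Oc2ccc(-c3noc(C)n3)cc2)ccn1` is the simpler analogue, with the same amide-pyridine ether on a single phenyl ring bearing a methyl-oxadiazole. For compound 2 this assay reports only a limit, > 100000 nM, so no number is known for it; it stands at the top of the values shown, at the limit of > 100000 nM in this assay, at which 1 of the 2 values shown sits. Compound 3 `CCc1nc(-c2ccc(Oc3ccnc(C(=O)NC)c3)cc2)no1` differs from compound 2 in one place: methyl in place of hydrogen on a saturated chain carbon bound to an aromatic carbon, in words, methyl in place of hydrogen on a saturated chain carbon bound to an aromatic carbon, so that the methyl-oxadiazole becomes an ethyl-oxadiazole. Among the compounds with values here, no measured pair shows this change, so the size of the step in this assay is not known from the data; a step within the usual scatter, in no particular direction, is expected. Compound 3 is accordingly expected to sit near the limit, with an estimate of 100000 nM and a range of 40000 nM to 200000 nM, which means an expected step of a number no higher from compound 2 to compound 3 (the limit leaves the size open) of essentially none.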

Compound 3, half-maximal cytotoxic concentration: 43700 nM
For compound 3 the middle estimate is 2.3-fold (0.36 log units) above the measured one, and the stated range covers the measured number.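

Within the data shown here, on the oxadiazole, methyl to ethyl is the first change that can be read as a step: in this assay it gives an at least 2.2-fold lower number from compound 2 to compound 3 (0.35 log units; beyond the scatter), so less of the ethyl compound is tolerated. This shows that the place on a saturated chain carbon bound to an aromatic carbon is not silent in this assay, and compound 3 gives the single-phenyl compounds their first actual number. For compound 2 the value > 100000 nM is a limit and not a number, so the step fixes only a minimum size and its full size stays unknown: the limit of > 100000 nM in this assay, at which 1 of the 3 values shown sits.

One step at one place cannot show whether the trend continues with a longer chain such as propyl. From the compounds shown here alone, the effect of an amine or a carboxylic acid on that chain also remains open.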